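The source may report more compounds than this note shows. Statements on the series, on what has been measured and on what is new or still open speak of the compounds shown alone.

Three compounds built on a shared core have been examined in an ADME assay on MDBK cells (Bos taurus) for cytotoxicity, read by MTT assay, with a stated time of 96 h; a higher number here means that more compound is tolerated, a lower number that less compound is tolerated. Compound 1 `Oc1ccc(-c2nc3cc(C(F)(F)F)ccc3[nH]2)cc1` carries a hydroxy group on its outer ring, and in this assay compound 1 gives 51000 nM. Of the two plain numbers recorded, that is the lowest, though only narrowly. Compound 2 `Cn1c(-c2ccc(N)cc2)nc2cc(C(F)(F)F)ccc21` gives 74000 nM in this assay, a value that sits within the usual scatter of compound 1, so the two cannot be ranked against each other. Compound 3 `COc1ccc(-c2nc3cc(C(F)(F)F)ccc3[nH]2)c(OC)c1OC` reaches only a limit of this assay, > 100000 nM, and no number is reported for it.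

Compound 4 `COc1ccc(-c2nc3cc(C(F)(F)F)ccc3[nH]2)cc1` has not yet been measured. It differs from compound 1 in one place: methyl in place of hydrogen on an oxygen on an aromatic ring. For the measured compounds named here, no pair of measured compounds here differs by exactly this change, so no measured step can serve as a yardstick. What can be said is that compound 3, which also carries methoxy groups on its outer ring, sits at the limit of > 100000 nM in this assay, at which 1 of the 3 values shown sits. On that basis a small step toward a higher number, or none beyond the scatter, is expected in this assay. The expected step is a 1.4-fold higher number from compound 1 to compound 4 (0.14 log units; within the scatter). Compound 4 is estimated at 70000 nM, with a likely range from 35000 nM to 140000 nM.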

Compound 4, half-maximal cytotoxic concentration: > 100000 nM
Compound 4 gave a limit, no number; the forecaster's own chance of this, stated with the estimate: 25%; middle value at least 1.4-fold (0.15 log units) from the limit.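

In this assay compound 4 reaches a limit of the assay, > 100000 nM, and no plain number is available for it. For the compounds shown here, replacing hydrogen with methyl on an oxygen on an aromatic ring, which turns hydroxy into methoxy, gives the one measured step for this change, an at least 1.9-fold higher number from compound 1 to compound 4 (0.29 log units; that floor lies within the scatter); this shows no move toward a lower number, but the true size of the step stays unknown and its floor does not clear the scatter. Compound 3 and compound 4, the two compounds shown that carry methoxy, now share the same limit: the limit of > 100000 nM in this assay, at which 2 of the 4 values shown sit.

The compounds shown leave open whether a longer chain on that oxygen, such as ethyl, or an amine in place of the hydroxy group would stay at this limit or give a plain number. On these data alone, how much of compound 4 could be tolerated beyond its limit also remains unknown, so the full effect of the methyl group cannot yet be sized.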